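Hydroxymethyl capping of the terminal alkyne in compound 1

The source may hold more compounds than are shown below. What is called first, only, known or untested is meant among the compounds shown, and "the series" means these compounds.

Compound 1 `C#CCCCn1c(Cc2cc(OC)c(OC)c(OC)c2)nc2c(N)ncnc21` stands second highest of the three numbers in a functional assay on SK-BR-3 cells (Homo sapiens) for cytotoxicity, with a stated time of 24 h (a higher number here means a weaker inhibitor, a lower number a stronger inhibitor), where compound 1 gives 31800 nM. Its nearer neighbour is compound 3 `COc1cc(Cc2nc3c(N)ncnc3n2CCCC#CCNCCCCCCCCCCCCN)cc(OC)c1OC`, which in this assay gives 13100 nM, a lower number beyond the scatter; the furthest is compound 2 `COc1cc(Cc2nc3c(N)ncnc3n2CCCC#CCNCCCCCCCCNCC#CCCCn2c(Cc3cc(OC)c(OC)c(OC)c3)nc3c(N)ncnc32)cc(OC)c1OC`, which in this assay gives 85700 nM, a higher number beyond the scatter. Going by the values given here, no pair of measured compounds differs in a single place, so no measured step is available. Compound 4 `COc1cc(Cc2nc3c(N)ncnc3n2CCCC#CCO)cc(OC)c1OC` differs from compound 1 by hydroxymethyl in place of hydrogen on a triple-bonded carbon. The numbers for compound 3 and compound 2 lie on either side of compound 1, so neither direction is indicated. The step of a 1.1-fold lower number from compound 1 to compound 4 (0.03 log units; within the scatter) is expected to stay within the scatter. Compound 4 is estimated at 30000 nM in this assay, with a range from 12000 nM to 75000 nM.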

Compound 4, half-maximal inhibitory concentration: > 100000 nM
Compound 4: only a limit was reported; the forecaster's own chance of this, stated with the estimate: 10%; at least 3.3-fold (0.52 log units) between middle value and limit.
By their numbers in this assay, from the lowest: compound 3; then compound 1; then compound 2. At a limit, above all of these: compound 4.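

In this assay, going by these compounds alone, hydroxymethyl in place of hydrogen on the triple-bonded carbon gives an at least 3.1-fold higher number from compound 1 to compound 4 (0.49 log units; beyond the scatter) and so offers the first single-place reading of this position, which the earlier compounds could not provide. This small change is enough to move the number beyond the scatter. Going by these compounds, for compound 4 the reading is a limit of the assay and not a number, so the full size of the step stays unknown: the limit of > 100000 nM in this assay, at which 1 of the 4 values shown sits.

On these data alone, whether a methyl, a methoxymethyl or a carboxylic acid on the same triple-bonded carbon would behave like hydroxymethyl stays open. The compounds shown give no reason for the step.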